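A few compounds are considered here, and "the series" means these few. Any claim that something is new, unique, unknown or untested is made for them only; others in the source may bear on it.

Measured so far in a functional assay on the whole organism (strain albino) for inhibition, with Rattus norvegicus as the target, read by paw edema, with stated times of 30 min and 4 h, at a dose of 0.28 mmol/kg by the oral route; a lower number here means less inhibition, a higher number more inhibition at the dose given (going by the name of the read-out):

compound 1, `C=CCn1c(SCC(=O)Nc2ccc(C(C)=O)cc2)nnc1-c1ccccc1`, gives 70%
compound 2, `C=CCn1c(SCC(=O)Nc2ccc(/C(C)=N/O)cc2)nnc1-c1ccc(OC)c(OC)c1`, gives 79%
compound 3, `C=CCn1c(SCC(=O)Nc2ccc(C(C)=O)cc2)nnc1-c1ccc(OC)cc1`, gives 68%

Compound 2 gives the highest of the three numbers; its gap to compound 1 lies within the scatter, its gap to compound 3 beyond it. No order among compound 1, compound 2 and compound 3 is claimed beyond that.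

One pair of measured compounds differs in a single place. From compound 1 to compound 3 the change is methoxy in place of hydrogen on an aromatic carbon and the step in this assay is a number 2 percentage points lower from compound 1 to compound 3 (within the scatter). The same kind of change leads from compound 2 to the unmeasured compound 4, `C=CCn1c(SCC(=O)Nc2ccc(/C(C)=N/O)cc2)nnc1-c1cc(OC)c(OC)c(OC)c1`: here it is methoxy in place of hydrogen on an aromatic carbon. The two places are not the same word for word: in the first case the entering group sits para to a large group, in the second it sits ortho to a methoxy group, meta to a large group and meta to a methoxy group, so this is the same kind of change, not the same change. The difference between the core of compound 1 and the core of compound 2 is not broken down here.

Going by the values given here, with only one measured instance of this kind of change, which stayed within the scatter, the expected step from compound 2 to compound 4 is a number 3 percentage points lower from compound 2 to compound 4 (within the scatter), resting on the earlier step from compound 1 to compound 3 and on the value of compound 2, 79%. Compound 4 is therefore estimated at 76% in this assay, with a range from 64% to 88%.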

Compound 4, a percentage reported as inhibition, in the whole organism at one dose (the size of the read-out at that dose, not a potency): 72%
Compound 4: middle estimate off by 4 percentage points, on the high side; measured number inside the range.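

Methoxy in place of hydrogen on an aromatic carbon gives a number 7 percentage points lower from compound 2 to compound 4 (within the scatter) in this assay. Set beside the earlier step, this change shows no difference between the two cores that can be told apart: the same change on two cores in this assay, a number 2 percentage points lower (within the scatter) from compound 1 to compound 3 and a number 7 percentage points lower (within the scatter) from compound 2 to compound 4, 5 percentage points apart, within the scatter of two such steps. This does not show that the step is the same on every core or at every place: there are only two instances, the entering methoxy sits at a different place in each, and neither step stands clear of the scatter, so a small effect of the change can be neither claimed nor excluded.

The compounds shown leave open whether a different group on the same aromatic carbon, such as an amine or a carboxylic acid, would move the inhibition of paw edema beyond the scatter. Also open, on these data alone, is how the methoxy change behaves at one and the same place on both cores.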